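Swapping Methoxy for Nitro on Two Related Cores

A few compounds are considered here, and "the series" means these few. Any claim that something is new, unique, unknown or untested is made for them only; others in the source may bear on it.

Measured in an assay on membranes from brain for displacement of a labelled ligand from Sigma non-opioid intracellular receptor 1 (Cavia porcellus), read by scintillation counting, with a stated time of 120 min; on this read-out higher numbers stand for weaker inhibition and lower numbers for stronger inhibition:
- compound 1, `COc1ccc(-c2scc3c2CC(OC)OC32CCN(Cc3ccccc3)CC2)cc1`, gives 2.2 nM
- compound 2, `COC1Cc2c(csc2-c2ccc([N+](=O)[O-])cc2)C2(CCN(Cc3ccccc3)CC2)O1`, gives 1 nM
- compound 3, `COc1ccc(-c2cc3c(s2)C2(CCN(Cc4ccccc4)CC2)OC(OC)C3)cc1`, gives 56 nM

Compound 1 and compound 2 share one core and differ in a single group: nitro in place of methoxy on an aromatic carbon. In this assay that single change made the step of a 2.2-fold lower number from compound 1 to compound 2 (0.34 log units; beyond the scatter), so compound 2 came out with the lower number.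

Compound 3 is built from the same atoms as compound 1, joined differently; the difference between the two cores is not broken down here. Of the three measured compounds, compound 3 has the highest number in this assay, and its steps to compound 1 and to compound 2 both lie beyond the usual scatter.

Compound 4, `COC1Cc2cc(-c3ccc([N+](=O)[O-])cc3)sc2C2(CCN(Cc3ccccc3)CC2)O1`, has not yet been measured. It stands to compound 3 exactly as compound 2 stands to compound 1: nitro in place of methoxy on an aromatic carbon. The description of the place where the group sits is the same word for word in both pairs, so this is the same change, only carried out on the core of compound 3 instead of the core of compound 1.

For the measured compounds named here, from compound 3 to compound 4 a step of about a 2.2-fold lower number from compound 3 to compound 4 (0.35 log units; beyond the scatter) is expected in this assay, because the one earlier example of this change gave a 2.2-fold lower number from compound 1 to compound 2 (0.34 log units; beyond the scatter). On that basis compound 4 is estimated to give about 25 nM, with a plausible range from 8 nM to 80 nM.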

Compound 4, inhibition constant: 16 nM
Beside the measured number, compound 4's estimate is 1.6-fold (0.19 log units) above it; low and high end bracket the measured number.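

In this assay, putting nitro in place of methoxy on the core of compound 3 gave a 3.5-fold lower number from compound 3 to compound 4 (0.54 log units; beyond the scatter), so the swap lowered the number on this core as well. Set beside the earlier example, the two steps point the same way and do not differ in size by more than two such steps would normally scatter: the same change on two cores in this assay, a 2.2-fold lower number (0.34 log units; beyond the scatter) from compound 1 to compound 2 and a 3.5-fold lower number (0.54 log units; beyond the scatter) from compound 3 to compound 4, 1.6-fold (0.20 log units) apart, within the scatter of two such steps. This supports treating the swap from 4-methoxyphenyl to 4-nitrophenyl as transferable between these two cores in this assay, but two pairs are a small sample: they do not explain why the number falls, and they do not show that the same step would appear on any third core.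

The compounds shown leave open whether other groups in the same place, such as an amine, a nitrile or a trifluoromethyl group, would move the number in the same direction on both cores. Also open is whether the swap would behave in the same way at any other receptor, since the only read-out shown here is this one binding measurement.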